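The source may hold more compounds than are shown below. What is called first, only, known or untested is meant among the compounds shown, and "the series" means these compounds.

The series shares one core, seen in compound 1 `O=[N+]([O-])c1ccc(NC(=S)NCCNS(=O)(=O)c2ccc(-c3ccccc3O[C@H]3CC[C@@H](O)CC3)s2)cc1` and compound 3 `O=[N+]([O-])c1ccc(NC(=S)NCCNS(=O)(=O)c2ccc(-c3ccccc3OCc3ccccc3)s2)cc1`, both carrying a 4-nitrophenyl thiourea. In a functional assay on HeLa cells (Homo sapiens) for inhibition, read by CCK-8 assay, with a stated time of 48 h (a lower number here means a stronger inhibitor, a higher number a weaker inhibitor), compound 3 gives 7100 nM. For compound 1 the assay reports only a limit, > 20000 nM (the limit of > 20000 nM in this assay, at which 1 of the 3 values shown sits). Within the data shown here, that pair yields the single measured step, an at least 2.8-fold lower number from compound 1 to compound 3 (0.44 log units; beyond the scatter), and it changes the ether substituent, not the thiourea aryl.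

Compound 2 `COc1cccc(NC(=S)NCCNS(=O)(=O)c2ccc(-c3ccccc3Oc3ccc([N+](=O)[O-])cc3)s2)c1` stands at a limit in this assay, > 50000 nM (the limit of > 50000 nM in this assay, at which 1 of the 3 values shown sits), so among the three values shown it is the one for which nothing more than a limit is known. Compound 4 `O=[N+]([O-])c1ccc(Oc2ccccc2-c2ccc(S(=O)(=O)NCCNC(=S)Nc3cccc(Cl)c3)s2)cc1` keeps everything in compound 2 except (chloro in place of methoxy on an aromatic carbon). Among the measured compounds shown here, no measured step touches this aryl on the thiourea, so the only step on record gives no guide to its size or direction, and no step beyond the scatter is expected in this assay. Compound 4 is therefore estimated at 40000 nM (range 10000 nM to 100000 nM), which would mean a step of an at least 1.2-fold lower number from compound 2 to compound 4 (0.09 log units; that floor lies within the scatter), expected to remain within scatter of the limit.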

Compound 4, half-maximal inhibitory concentration: 4600 nM
Beside the measured number, compound 4's estimate is 8.7-fold (0.94 log units) above it; measured number outside the range, below it.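

Replacing methoxy with chloro on an aromatic carbon, meta to a large group, gives an at least 10-fold lower number from compound 2 to compound 4 (1.03 log units; beyond the scatter). Among these compounds, the one earlier step changed the ether substituent, so this is the first sign that the aryl on the thiourea can also shift the number in this assay, and by a large amount. The size of this step is only a floor, because compound 2 stands at a limit rather than at a number: the limit of > 50000 nM in this assay, at which 1 of the 4 values shown sits.

The compounds shown leave open whether the change depends on chloro itself, since a plain phenyl, 3-fluorophenyl or 3-aminophenyl on the thiourea would separate the gain from chloro from the loss of methoxy. They also leave open whether 3-chlorophenyl would bring a similar step on the benzyl ether of compound 3.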